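The source may report more compounds than this note shows. Statements on the series, on what has been measured and on what is new or still open speak of the compounds shown alone.

Compound 1 `CC(C)Cc1ncc2c(N)c(C#N)c(N)nc2n1` gives 268000 nM in a physicochemical assay for solubility, in phosphate buffer, with a stated time of 18 h; on this read-out higher numbers stand for higher solubility and lower numbers for lower solubility. Among the measured compounds shown here, compound 2 `CC(C)(C)c1ncc2c(N)c(C#N)c(N)nc2n1` gives 37200 nM in this assay, the lowest of the two numbers, and the single measured step, a 7.2-fold lower number from compound 1 to compound 2 (0.86 log units; beyond the scatter), lies beyond the scatter. Compound 3 `CC(C)(C)c1nc(-c2ccsc2)c2c(N)c(C#N)c(N)nc2n1` differs from compound 2 by thiophen-3-yl in place of hydrogen on an aromatic carbon. For the measured compounds named here, no measured step bears directly on this change, because the only known step, a 7.2-fold lower number from compound 1 to compound 2 (0.86 log units; beyond the scatter), alters just the alkyl group, so the expectation rests on the low starting point of compound 2 alone; a further, modest decrease in this assay is expected, a 4.7-fold lower number from compound 2 to compound 3 (0.67 log units; beyond the scatter). Compound 3 is accordingly estimated at 8000 nM, within a range from 2000 nM to 30000 nM.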

Compound 3, solubility: 40000 nM
For compound 3 the middle estimate is 5.0-fold (0.70 log units) below the measured one, and the stated range ends below it.
By their numbers in this assay, from the lowest: compounds 2 and 3 (each within the scatter of the next); then compound 1.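

In this assay, thiophen-3-yl in place of hydrogen on an aromatic carbon meta to a tert-butyl group gives a 1.1-fold higher number from compound 2 to compound 3 (0.03 log units; within the scatter) and so leaves the read-out level within the scatter. Among the compounds shown here, the earlier step changed only the alkyl group, so this is the first reading at this carbon, and it shows that this aromatic ring can enter here without a step beyond the scatter. No measured evidence explains this result.

From the compounds shown here alone, whether an amine or a carboxylic acid at this carbon would also stay level remains open. So does whether thiophen-3-yl would behave the same alongside the isobutyl group of compound 1.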